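The source may report more compounds than this note shows. Statements on the series, on what has been measured and on what is new or still open speak of the compounds shown alone.

Compound 1 `CC(C)c1ccc(-c2nc(SCc3cn(CC(=O)NC(=O)Nc4ccccn4)nn3)nc(Nc3ccc(Cl)cc3)c2C#N)cc1` reaches only the limit of a functional assay on MCF7 cells (Homo sapiens) for inhibition, read by MTT assay, with a stated time of 72 h (on this read-out lower numbers stand for stronger inhibition and higher numbers for weaker inhibition), where compound 1 gives > 64000 nM. Within the data shown here, compound 2 `COc1ccccc1Nc1nc(SCc2cn(CC(=O)NC(=O)Nc3ccccn3)nn2)nc(-c2ccc(C(C)C)cc2)c1C#N` in this assay gives 19300 nM, the only actual number among the two results. The other result, that of compound 1, is a limit (the limit of > 64000 nM in this assay, at which 1 of the 2 values shown sits). The step of an at least 3.3-fold lower number from compound 1 to compound 2 (0.52 log units; beyond the scatter) replaced the aryl group on the nitrogen. Compound 3 `CC(C)c1ccc(-c2nc(SCc3cn(CC(=O)NC(=O)Nc4ccccn4)nn3)nc(Nc3ccccc3O)c2C#N)cc1` differs from compound 2 by hydrogen in place of methyl on an oxygen on an aromatic ring. Among the measured compounds shown here, no measured step alters this oxygen, so nothing observed bears directly on the change. For compound 3 the expected step is no change at the digits printed from compound 2 to compound 3 (within the scatter), none beyond the scatter. Compound 3 is therefore estimated at 19300 nM, between 6000 nM and 64000 nM.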

Compound 3, half-maximal inhibitory concentration: > 64000 nM
Compound 3: only a limit was reported (the forecaster's own chance of this, stated with the estimate: 25%); at least 3.3-fold (0.52 log units) between middle value and limit.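

Changing methoxy to hydroxy on the aromatic ring gives an at least 3.3-fold higher number from compound 2 to compound 3 (0.52 log units; beyond the scatter) in this assay, so the methyl on this oxygen matters: with hydrogen in its place, the measurable inhibition of compound 2 is not kept. Compound 1 and compound 3 both rest at a limit, so the step between them cannot be read. Compound 2 alone gives an actual number, and the other results are limits: the limit of > 64000 nM in this assay, at which 2 of the 3 values shown sit.

From the compounds shown here alone, whether an ethoxy group, a longer chain on this oxygen or an amine in place of the methoxy would keep or lower the number of compound 2 remains open.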